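Working notes: 2-methylbenzyl to 4-nitrobenzyl on the shared core

The compounds below may be only part of what the source reports. "The series", "measured", "known", "first", "only" and "open" are said of these compounds alone.

In a functional assay on HepG2 cells (Homo sapiens) for antiproliferative activity, read by MTT assay, with a stated time of 24 h (on this read-out higher numbers stand for weaker inhibition and lower numbers for stronger inhibition), compound 1 `COc1cc(OC)c(-c2coc3cc(OCc4ccccc4)ccc3c2=O)cc1OC` gives 1320 nM as the reference point for this short series. Compound 2 `COc1cc(OC)c(-c2coc3cc(OCc4ccccc4C)ccc3c2=O)cc1OC` gives 1860 nM and stands within the scatter of compound 1, so the pair shows no order. For the measured compounds named here, the only measured step is a 1.4-fold higher number from compound 1 to compound 2 (0.15 log units; within the scatter) with methyl in place of hydrogen on an aromatic carbon.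

Compound 3 `COc1cc(OC)c(-c2coc3cc(OCc4ccc([N+](=O)[O-])cc4)ccc3c2=O)cc1OC` is next, with 4-nitrophenyl in place of 2-methylphenyl on a saturated chain carbon bound to an oxygen on an aromatic ring so that (2-methylbenzyl)oxy becomes (4-nitrobenzyl)oxy. Going by the values given here, no compound with 4-nitrophenyl has been measured yet, which leaves a single and only loosely related step as a guide. Among the compounds with values here, a shift within the scatter is the working expectation because a 1.4-fold higher number from compound 1 to compound 2 (0.15 log units; within the scatter) is the only evidence on this part of the series. The expected change is a 1.2-fold lower number from compound 2 to compound 3 (0.09 log units; within the scatter) in this assay and so none beyond the scatter. Compound 3 is estimated at 1500 nM within an expected range of 600 nM to 3800 nM on this limited evidence.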

Compound 3, half-maximal inhibitory concentration: 2500 nM
For compound 3 the middle estimate is 1.7-fold (0.22 log units) below the measured one, and the stated range covers the measured number.
By their numbers in this assay, from the lowest: compounds 1, 2 and 3 (each within the scatter of the next).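

In this assay, 4-nitrophenyl in place of 2-methylphenyl on a saturated chain carbon bound to an oxygen on an aromatic ring gives a 1.3-fold higher number from compound 2 to compound 3 (0.13 log units; within the scatter) and so separates neither group from the other. Adding a nitro group to the aromatic ring gives a 1.9-fold higher number from compound 1 to compound 3 (0.28 log units; within the scatter) and also stays within the scatter, so this part of the series now tolerates two different additions to the ring of compound 1 without a readable difference in this assay. Nothing available on these compounds accounts for the values or connects them to the groups involved.

The compounds shown leave open whether any change at this position can produce a difference beyond the scatter, since all three values remain too close to set an order. An amine or a carboxylic acid on the same aromatic ring, or a longer chain in place of the single saturated carbon bound to the oxygen, would test that question more widely than methyl and nitro can.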